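A few compounds are considered here, and "the series" means these few. Any claim that something is new, unique, unknown or untested is made for them only; others in the source may bear on it.

Measured in a functional assay on DU-145 cells (Homo sapiens) for antiproliferative activity, read by propidium iodide staining, with a stated time of 96 h; on this read-out lower numbers stand for stronger inhibition and higher numbers for weaker inhibition:
- compound 1 `CC(O)(CSc1cccc(OC(F)(F)F)c1)C(=O)Nc1cccc(S(F)(F)(F)(F)F)c1`: 25000 nM
- compound 2 `CC(O)(COc1ccc(C#N)cc1C(F)(F)F)C(=O)Nc1ccc(S(F)(F)(F)(F)F)cc1`: 21200 nM
- compound 3 `CC(O)(COc1cccc(S(F)(F)(F)(F)F)c1)C(=O)Nc1cccc(S(F)(F)(F)(F)F)c1`: 30700 nM

Compound 3, at 30700 nM, lies within the scatter of both compound 1 and compound 2, so the three values cannot be told apart. Compound 4 `CC(O)(COc1cccc(C(F)(F)F)c1)C(=O)Nc1cccc(S(F)(F)(F)(F)F)c1` differs from compound 3 in one place, where trifluoromethyl enters on an aromatic carbon: a group of 4 heavy atoms (1 carbon, 3 fluorine; no ring) in place of a group of 6 heavy atoms (5 fluorine, 1 sulfur; no ring), on an aromatic carbon. For the measured compounds named here, no measured pair differs in one place only, so the data offer no direct precedent. Even so, the three structurally different compounds share one level, and no step beyond the scatter is expected in this assay, in either direction. The estimate amounts to an expected 1.2-fold lower number from compound 3 to compound 4 (0.07 log units; within the scatter). For compound 4, the estimated value is 26000 nM, with an expected range of 13000 nM to 48000 nM.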

Compound 4, half-maximal inhibitory concentration: 31700 nM
Compound 4: middle estimate off by 1.2-fold (0.09 log units), on the low side; low and high end bracket the measured number.
By their numbers in this assay, from the lowest: compounds 2, 1, 3 and 4 (each within the scatter of the next).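

In this assay, for the compounds shown here, the exchange of the group of 6 heavy atoms (5 fluorine, 1 sulfur) for trifluoromethyl on this aromatic carbon gives a 1.0-fold higher number from compound 3 to compound 4 (0.01 log units; within the scatter) and is the first one-place step available, so the two compounds cannot be told apart. This position therefore accepts either group at one level in this assay. No measured property bears on this result. From the compounds shown here alone, what stays open is whether an amine or a carboxylic acid on the same carbon would shift the number beyond the scatter.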